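The compounds below may be only part of what the source reports. "The series", "measured", "known", "first", "only" and "open" are said of these compounds alone.

Compound 1 `N#Cc1ccccc1-c1cccc(CNc2ccc(OCC(=O)O)c(F)c2)c1` gives 729 nM in a functional assay on CHO cells for agonist activity at Free fatty acid receptor 1 (Homo sapiens), read by FLIPR and calcium flux; on this read-out lower numbers stand for an effect already at smaller amounts and higher numbers for an effect only at larger amounts of compound. Compound 2 `CCOc1ccc(-c2cccc(CNc3ccc(OCC(=O)O)c(F)c3)c2)c(C)c1` gives 11.6 nM in this assay.

Among the compounds with values here, on these two numbers compound 2 stands lowest; its only neighbour is compound 1, and the single measured step, a 63-fold lower number from compound 1 to compound 2 (1.80 log units; beyond the scatter), came from exchanging the whole aryl group attached to the shared core. Compound 3 `Cc1cc(OCCCS(C)(=O)=O)ccc1-c1cccc(CNc2ccc(OCC(=O)O)c(F)c2)c1` differs from compound 2 in another place: (methylsulfonyl)methyl in place of hydrogen on a saturated chain carbon, two bonds along the chain from an oxygen on an aromatic ring. Within the data shown here, no measured step touches this chain; the step from compound 1 to compound 2 concerns the aryl group itself and not the chain on its oxygen, so it offers no direct guide. With nothing to point either way, no step beyond the scatter is expected, and for compound 3 the expected step is a 1.3-fold higher number from compound 2 to compound 3 (0.11 log units; within the scatter). Compound 3 is thus estimated at 15 nM, within a range from 4 nM to 60 nM.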

Compound 3, half-maximal effective concentration: 45.6 nM
Compound 3: middle estimate off by 3.0-fold (0.48 log units), on the low side; the range from low to high includes it.
By their numbers in this assay, from the lowest: compound 2; then compound 3; then compound 1.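

In this assay, the chain on the aromatic oxygen proves to be a place that responds to change: going from ethoxy to 3-(methylsulfonyl)propoxy gives a 3.9-fold higher number from compound 2 to compound 3 (0.59 log units; beyond the scatter). The response is modest for an addition of 5 heavy atoms, and compound 3 remains at 45.6 nM, so this chain accepts a substantial extension without a large move in the number. The data available offer no measured explanation for the step.

Going by these compounds, what stays open is whether the step belongs to the longer chain itself or to the methylsulfonyl end of it, a question that a plain propoxy chain would address. On these data alone, it is also open how the number would move with an amine or a carboxylic acid at the end of the chain, or with a longer chain.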